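This account rests on a few compounds, and the source may have more. Where it says the series, first, only, none or still open, it means among the compounds named here.

Measured compounds and their values:

Compound 1 `CCOc1ccc(C(=O)/C=C/c2c(/C=C/c3ccc(OC)cc3)cc(OC)cc2OC)cc1` gives 8 ug/mL in a functional assay on HepG2 cells (Homo sapiens) for antiproliferative activity, read by MTT assay, with a stated time of 48 h; on this read-out higher numbers stand for weaker inhibition and lower numbers for stronger inhibition.
Compound 2 `COc1ccc(/C=C/c2cc(OC)cc(OC)c2/C=C/C(=O)c2cccc(Cl)c2)cc1` gives 9.5 ug/mL in this assay.
Compound 3 `CCCCCCCCCCCCOc1ccc(C(=O)/C=C/c2c(/C=C/c3ccc(OC)cc3)cc(OC)cc2OC)cc1` gives 11.6 ug/mL in this assay.

Compound 2 stands second highest of the three numbers in this assay. Its nearest neighbour is compound 1, separated by a 1.2-fold higher number from compound 1 to compound 2 (0.07 log units; within the scatter); compound 3 lies on the other side of compound 2, and the two values of compound 2 and compound 3 sit within the scatter of each other, so no order between them can be read.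

Compound 4 `COc1ccc(/C=C/c2cc(OC)cc(OC)c2/C=C/C(=O)c2ccc(-c3ccccc3)cc2)cc1` has not yet been measured. It differs from compound 2 in one place: 4-phenylphenyl in place of 3-chlorophenyl on a carbonyl carbon.

The step that bears most directly on this change is the one at the same carbonyl carbon, a 1.2-fold higher number from compound 1 to compound 2 (0.07 log units; within the scatter), where one aryl group replaced another without a shift beyond the scatter. Within the data shown here, the only other step seen, a 1.5-fold higher number from compound 1 to compound 3 (0.16 log units; within the scatter), also stayed within the scatter despite a large change in size elsewhere. On that basis compound 4 is expected to show a step of a 1.2-fold higher number from compound 2 to compound 4 (0.06 log units; within the scatter) in this assay, that is, nothing beyond the scatter, with a slight lean toward a higher number since the largest compound measured, compound 3, gave the highest number. The estimate for compound 4 in this assay is 11 ug/mL, with a range from 5 ug/mL to 24 ug/mL.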

Compound 4, half-maximal inhibitory concentration: 10.5 ug/mL
Compound 4: middle estimate off by 1.0-fold (0.02 log units), on the high side; low and high end bracket the measured number.
By their numbers in this assay, from the lowest: compounds 1, 2, 4 and 3 (each within the scatter of the next).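

In this assay, the change on the carbonyl carbon from 3-chlorophenyl, with 7 heavy atoms, to 4-phenylphenyl, with 12 heavy atoms and a second six-membered aromatic ring of carbon only, gave a 1.1-fold higher number from compound 2 to compound 4 (0.04 log units; within the scatter), so this position accepted a much larger aryl group without a shift beyond the scatter. Against the 4-ethoxyphenyl group of compound 1, the same biaryl group gave a 1.3-fold higher number from compound 1 to compound 4 (0.12 log units; within the scatter), which means that three different aryl groups at this carbon, rather than the two seen before, now lie within the scatter of one another. The compounds shown offer no independent measurement that could explain why the values stay so close together.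

Going by these compounds, all the groups compared here at the carbonyl carbon are aryl groups without a basic or acidic function, so it remains open whether an aminomethyl group or a carboxylic acid on that ring would move the number beyond the scatter. On these data alone, it also remains open whether a saturated ring such as cyclohexyl, in place of the aryl group, would leave the number within the scatter in this assay.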